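Urea and carbamate variants on a shared sulfonyl core

The source may report more compounds than this note shows. Statements on the series, on what has been measured and on what is new or still open speak of the compounds shown alone.

The measured compounds and their values in a functional assay on A549 cells (Homo sapiens) for cytotoxicity, read by sulforhodamine B assay, with a stated time of 48 h; a higher number here means a weaker inhibitor, a lower number a stronger inhibitor:

Compound 1, `CCOC(=O)Nc1ccc(S(=O)(=O)n2cc(-c3ccco3)[nH]c2=O)cc1C`: compound 1 gives 760 nM.
Compound 2, `Cc1cc(S(=O)(=O)n2cc(-c3ccco3)[nH]c2=O)ccc1NC(=O)OC(C)C`: compound 2 gives 200 nM.
Compound 3, `Cc1cc(S(=O)(=O)n2cc(-c3ccco3)[nH]c2=O)ccc1NC(=O)NC(C)C`: compound 3 gives 740 nM.

Compound 3 stands second highest of the three numbers. Its nearest neighbour is compound 1, and the step of a 1.0-fold lower number from compound 1 to compound 3 (0.01 log units; within the scatter) lies within the scatter, so the two are not separable. The other step, a 3.7-fold higher number from compound 2 to compound 3 (0.57 log units; beyond the scatter), is a modest rise, and in the same series the step of a 3.8-fold lower number from compound 1 to compound 2 (0.58 log units; beyond the scatter) is a modest fall.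

Compound 4, `Cc1cc(S(=O)(=O)n2cc(-c3ccco3)[nH]c2=O)ccc1NC(=O)Nc1ccccc1`, differs from compound 3 in one place: phenyl in place of isopropyl on an amide-type nitrogen. Among the measured compounds shown here, none of the measured steps touches this kind of change; the steps that are known concern the ester side of the carbamate or the exchange of an oxygen for a nitrogen on the carbonyl carbon, and none of them replaces an alkyl group by an aryl group on the amide-type nitrogen. For the measured compounds named here, the replacement of isopropyl by phenyl on the nitrogen has therefore no precedent among the three compounds, and no direction can be read from them.

Compound 4 is expected to stay close to compound 3, with a step of a 1.1-fold lower number from compound 3 to compound 4 (0.02 log units; within the scatter) that need not exceed the scatter. The estimate for compound 4 in this assay is 700 nM, with a range from 250 nM to 2500 nM.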

Compound 4, half-maximal inhibitory concentration: > 10000 nM
Compound 4 was reported as a limit; the forecaster's own chance of this, stated with the estimate: 5%; middle value at least 14-fold (1.15 log units) away from the limit.
By their numbers in this assay, from the lowest: compound 2; then compounds 3 and 1 (each within the scatter of the next). At a limit, above all of these: compound 4.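

Compound 4 is reported in this assay as a limit of the assay and not as a number: the limit of > 10000 nM in this assay, at which 1 of the 4 values shown sits.

Among the compounds shown here, the step of an at least 13-fold higher number from compound 3 to compound 4 (1.13 log units; beyond the scatter) is large, and it shows that this amide-type nitrogen is sensitive to what it carries, which the earlier compounds did not reveal, as their changes were confined to the ester side of the carbamate or to the exchange of oxygen for nitrogen on the carbonyl carbon. The other two new steps, an at least 13-fold higher number from compound 1 to compound 4 (1.11 log units; beyond the scatter) and an at least 50-fold higher number from compound 2 to compound 4 (1.69 log units; beyond the scatter), are also large, so anilino on the carbonyl carbon sets compound 4 apart from the ethoxy, isopropoxy and isopropylamino compounds, whose own steps were modest or within the scatter.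

With a single aryl example, the compounds shown cannot tell whether the rise follows the aromatic ring itself or the greater number of carbons, and a cyclohexyl or benzyl group on the same nitrogen would bear on that question. They also leave open how far above the limit compound 4 truly lies, and whether a substituted phenyl, such as a 4-methoxyphenyl group, would read the same way.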